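The source may hold more compounds than are shown below. What is called first, only, known or untested is meant among the compounds shown, and "the series" means these compounds.

Compound 1 `COc1ncc(-c2ccc3ncnc(Nc4ccc(OCCCO)nc4)c3c2)cc1NS(=O)(=O)c1ccc(F)cc1F` carries the highest number of the three measured compounds: in a functional assay on A549 cells (Homo sapiens) for antiproliferative activity, read by sulforhodamine B assay, with a stated time of 72 h (on this read-out lower numbers stand for stronger inhibition and higher numbers for weaker inhibition), compound 1 gives 9360 nM. Compound 3 `COc1ncc(-c2ccc3ncnc(Nc4ccc(OCCO)nc4)c3c2)cc1NS(C)(=O)=O` gives 5080 nM, a lower number that still lies within the scatter of the value of compound 1, while compound 2 `COc1ncc(-c2ccc3ncnc(Nc4cnn(CCC(=O)O)c4)c3c2)cc1NS(C)(=O)=O` gives 3840 nM, lower by a gap that lies beyond the scatter. Compound 4 `COc1ncc(-c2ccc3ncnc(Nc4cnn(CCCO)c4)c3c2)cc1NS(=O)(=O)c1ccc(F)cc1F` differs from compound 1 in one place: 1-(3-hydroxypropyl)-1H-pyrazol-4-yl in place of 6-(3-hydroxypropoxy)pyridin-3-yl on a nitrogen on an aromatic ring. Among the compounds with values here, the only measured step that bears on this exchange runs the other way, from a pyrazolyl to a pyridinyl partner on a nitrogen on an aromatic ring, each with a different chain: a 1.3-fold higher number from compound 2 to compound 3 (0.12 log units; within the scatter). Read in reverse, that step suggests that putting the pyrazole in place of the pyridine changes the number little, with at most a slight lowering. Compound 4 is therefore expected to stay close, with an estimated step of a 1.3-fold lower number from compound 1 to compound 4 (0.13 log units; within the scatter). The estimate for compound 4 in this assay is 7000 nM, with a range from 2500 nM to 20000 nM.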

Compound 4, half-maximal inhibitory concentration: 4830 nM
For compound 4 the middle estimate is 1.4-fold (0.16 log units) above the measured one; the measured number falls inside the stated range.
By their numbers in this assay, from the lowest: compounds 2, 4, 3 and 1 (each within the scatter of the next, the first and the last beyond it).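

With the 3-hydroxypropyl chain kept on both partners, exchanging the pyridine for the pyrazole on this nitrogen gives a 1.9-fold lower number from compound 1 to compound 4 (0.29 log units; within the scatter) in this assay. Within the data shown here, the earlier step between these two ring types also changed the chain, so this is the first reading of the ring exchange with the chain held, and it shows that this position takes the five-membered partner in place of the six-membered one without a change beyond the scatter. No measurement at hand accounts for the size of this step.

The compounds shown leave open whether an amine or a morpholine in place of the hydroxyl on the 3-hydroxypropyl chain would shift the number beyond the scatter. They also leave open whether the same ring exchange reads alike on the methanesulfonamide of compound 3.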